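The compounds below may be only part of what the source reports. "The series", "measured", "known", "first", "only" and "open" are said of these compounds alone.

Compound 3 `CC(C)CN1Cc2cccc(Oc3ncccc3NC(=O)Nc3ccc(OC(F)(F)F)cc3)c2C1` gives 68 nM in an assay on HEK293 cells for displacement of a labelled ligand from P2Y purinoceptor 1 (Homo sapiens), read by scintillation counting, with a stated time of 1 h (a lower number here means a stronger inhibitor, a higher number a weaker inhibitor), placing it second highest of the three numbers: compound 1 `CC(C)(C)CN1CCc2c(cccc2Oc2ncccc2NC(=O)Nc2ccc(OC(F)(F)F)cc2)C1` gives 11 nM, while compound 2 `CCCN1CCc2c(cccc2Oc2ncccc2NC(=O)Nc2ccc(OC(F)(F)F)cc2)C1` gives 620 nM. Compound 4 `CN1Cc2cccc(Oc3ncccc3NC(=O)Nc3ccc(OC(F)(F)F)cc3)c2C1` differs from compound 3 by hydrogen in place of isopropyl on a saturated chain carbon bound to an amine nitrogen in a ring; the same difference, cut one bond further out, reads isobutyl to methyl. Among the compounds with values here, the only measured step that bears on it is a 56-fold higher number from compound 1 to compound 2 (1.75 log units; beyond the scatter), where a smaller group was set on the same place, at a saturated chain carbon bound to an amine nitrogen in a ring. A shrinking of the same kind is expected to raise the number for compound 4, with a step of a 44-fold higher number from compound 3 to compound 4 (1.64 log units; beyond the scatter). Compound 4 is therefore estimated at 3000 nM, within a range from 600 nM to 15000 nM.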

Compound 4, inhibition constant: 3700 nM
For compound 4 the middle estimate is 1.2-fold (0.09 log units) below the measured one, and the stated range covers the measured number.
By their numbers in this assay, from the lowest: compound 1; then compound 3; then compound 2; then compound 4.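

Shrinking the group at this position, a saturated chain carbon bound to an amine nitrogen in a ring, costs strongly on a second core: hydrogen in place of isopropyl, or isobutyl to methyl, gives a 54-fold higher number from compound 3 to compound 4 (1.74 log units; beyond the scatter). The large loss is therefore not confined to the core of compound 1, where the earlier step was seen. Compound 4, with only methyl left, is the weakest inhibitor of the four.

Going by these compounds, whether a cyclohexyl ring or a hydroxyl group on this chain would restore inhibition remains open. No measurement here explains why the smaller groups give weaker inhibitors.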